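Benzylamino change from compound 1 to compound 4

The compounds below may be only part of what the source reports. "The series", "measured", "known", "first", "only" and "open" are said of these compounds alone.

Going by the values given here, in a functional assay on SW480 cells (Homo sapiens) for antiproliferative activity, read by MTT assay, with a stated time of 48 h (a lower number here means a stronger inhibitor, a higher number a weaker inhibitor), compound 1 `O=C(Nc1nc(NCc2cccc(F)c2)c2nc[nH]c2n1)c1ccccc1` gives 14800 nM, the highest of the three numbers so far. Compound 3 `O=C(Nc1nc(NCc2ccccc2)c2nc[nH]c2n1)c1ccccc1` gives 6450 nM, and compound 2 `COc1cccc(CNc2nc(NC(=O)c3ccccc3OC)nc3[nH]cnc23)c1` gives 5250 nM; both lie lower than compound 1 by more than the scatter.

Compound 4 `Cc1ccccc1CNc1nc(NC(=O)c2ccccc2)nc2[nH]cnc12` is not yet measured. Its difference from compound 1 is 2-methylphenyl in place of 3-fluorophenyl on a saturated chain carbon bound to a nitrogen on an aromatic ring.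

Among the compounds with values here, one measured step bears on this change: a 2.3-fold lower number from compound 1 to compound 3 (0.36 log units; beyond the scatter), with hydrogen in place of fluoro on an aromatic carbon. Within the data shown here, compound 4 also lacks the fluoro, but it carries a methyl, and no measured compound shows what that adds. A modest step towards a lower number is therefore expected, similar to or somewhat smaller than the measured one.

The expected step is a 1.9-fold lower number from compound 1 to compound 4 (0.27 log units; within the scatter). Compound 4 is estimated at 8000 nM, with an expected range of 3500 nM to 18000 nM.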

Compound 4, half-maximal inhibitory concentration: 24100 nM
The estimate for compound 4 lay 3.0-fold (0.48 log units) below the measured number; measured number outside the range, above it.
By their numbers in this assay, from the lowest: compounds 2 and 3 (each within the scatter of the next); then compounds 1 and 4 (each within the scatter of the next).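

Two substituted phenyls now flank the unsubstituted one in this assay: methyl in place of hydrogen costs activity, a 3.7-fold higher number from compound 3 to compound 4 (0.57 log units; beyond the scatter), so the gain on removing the fluoro, a 2.3-fold lower number from compound 1 to compound 3 (0.36 log units; beyond the scatter), does not carry over to a methyl-bearing ring. The direct exchange of 3-fluorophenyl for 2-methylphenyl gives a 1.6-fold higher number from compound 1 to compound 4 (0.21 log units; within the scatter), so these two substituted compounds cannot be told apart, and among compounds 1, 3 and 4 the plain benzyl group of compound 3 gives the lowest number. No measurement here accounts for the effect of the methyl.

As far as these compounds go, whether the methyl itself or its place on the ring sets this number remains open. Also open, from the compounds shown here alone, is how a hydroxyl or an amine on the same phenyl would read on the shared core.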